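Two sulfonylurea analogues, one with a propylcarbamoyl group

A few compounds are considered here, and "the series" means these few. Any claim that something is new, unique, unknown or untested is made for them only; others in the source may bear on it.

compound 1 `C=CCNC(=S)NS(=O)(=O)c1ccc(-n2nc(C(=O)O)cc2C)cc1`: -6%
compound 2 `Cc1cc(C(=O)O)nn1-c1ccc(S(=O)(=O)NC(=S)Nc2ccccc2)cc1`: 0%

In a functional assay on the whole organism (blood, strain albino) with Mus musculus as the target, with stated times of 6 days and 4 h, at a dose of 0.4 mmol/kg by the oral route (on this read-out lower numbers stand for less inhibition and higher numbers for more inhibition at the one dose given (going by the name of the read-out)), compound 2 gives 0%, the higher of the two numbers shown. Its nearest neighbour is compound 1, which in this assay gives -6%. Among the measured compounds shown here, the only measured step, a number 6 percentage points higher from compound 1 to compound 2 (within the scatter), is a change of phenyl in place of allyl on an amide-type nitrogen, and it lies within the scatter; neither compound shows inhibition beyond the scatter in this assay.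

The unmeasured compound 3 `CCCNC(=O)NS(=O)(=O)c1ccc(-n2nc(C(=O)O)cc2C)cc1` differs from compound 2 at the sulfonamide nitrogen: a group of 6 heavy atoms (4 carbon, 1 nitrogen, 1 oxygen; no ring) in place of a group of 9 heavy atoms (7 carbon, 1 nitrogen, 1 sulfur; one six-membered aromatic ring of carbon only), on a sulfonamide nitrogen. For the measured compounds named here, no measured step touches this part of the structure, so the step from the allyl to the phenyl group is the only guide, and it was flat. With that flat step, compound 2 sitting at no inhibition, and nothing in the data pointing the change either way, a step of no change at the digits printed from compound 2 to compound 3 (within the scatter) is expected, none beyond the scatter. For compound 3 the estimated value in this assay is 0%, with a range from -15% to 15%.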

Compound 3, a percentage reported as inhibition, in the whole organism at one dose (the size of the read-out at that dose, not a potency): 1%
Compound 3: middle estimate off by 1 percentage points, on the low side, within the range that was stated.
By their numbers in this assay, from the lowest: compounds 1, 2 and 3 (each within the scatter of the next).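

Swapping the whole group on the sulfonamide nitrogen for propylcarbamoyl, which also removes the six-membered aromatic ring, gives in this assay a number 1 percentage points higher from compound 2 to compound 3 (within the scatter). The earlier compounds shown here varied only the allyl and phenyl groups on a sulfur-bearing group, whereas compound 3 carries an oxygen-bearing group at this position, and the comparison with the allyl compound of equal heavy-atom count gives a number 7 percentage points higher from compound 1 to compound 3 (within the scatter). Across these changes in ring content and in sulfur or oxygen, none of the three compounds separates from another in this assay, and none shows inhibition beyond the scatter. Nothing available accounts for how closely these numbers sit together.

The compounds shown leave open whether any group on this sulfonamide nitrogen can lift the read-out beyond the scatter at this one dose, for instance a longer chain such as hexyl or a cyclohexyl ring in place of propyl. They also leave open whether the flat picture would hold with the carboxylic acid of the shared core exchanged for an ethyl ester or an amide.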